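Chloro in Place of Nitro: What to Expect for Compound 4

This account rests on a few compounds, and the source may have more. Where it says the series, first, only, none or still open, it means among the compounds named here.

Measured so far:
compound 1 `COc1cc(C2CC(c3ccc(OCc4cn(Cc5ccc([N+](=O)[O-])cc5)nn4)cc3)=NN2C(C)=O)ccc1Oc1cn(Cc2ccc([N+](=O)[O-])cc2)nn1` gives 42%
compound 2 `COc1cc(C2CC(c3ccc([N+](=O)[O-])cc3)=NN2C(C)=O)ccc1OCc1cn(Cc2ccc([N+](=O)[O-])cc2)nn1` gives 72%
compound 3 `COc1cc(C2CC(c3cccc4ccccc34)=NN2C(C)=O)ccc1OCc1cn(Cc2ccc([N+](=O)[O-])cc2)nn1` gives 95%

All three were tested in a functional assay on A549 cells (Homo sapiens) for inhibition, read by sulforhodamine B assay, tested at 100 uM; a lower number here means less inhibition of growth, a higher number more inhibition of growth at the concentration tested. Compound 2 stands second highest of the three numbers: compound 3 lies above it, by a number 23 percentage points higher from compound 2 to compound 3 (beyond the scatter), while compound 1 lies well below it, and both gaps lie beyond the scatter.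

Compound 4 `COc1cc(C2CC(c3ccc(Cl)cc3)=NN2C(C)=O)ccc1OCc1cn(Cc2ccc([N+](=O)[O-])cc2)nn1` is not yet measured. It differs from compound 2 in one place: chloro in place of nitro on an aromatic carbon.

Going by the values given here, no measured pair shows exactly this change. Among the compounds with values here, the only single-point step at the same aromatic carbon is the one from compound 2 to compound 3, where naphthalen-1-yl replaced 4-nitrophenyl and inhibition rose by a modest amount beyond the scatter. That shows this position can move the number, but gives no direction for chloro. Compound 1 differs in more than one place and cannot be read as a step.

Compound 4 is therefore expected to land near compound 2, with a step of about a number 3 percentage points higher from compound 2 to compound 4 (within the scatter), which is within the scatter. The estimate for compound 4 is 75%, with a range from 50% to 95%.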

Compound 4, percent growth inhibition at one concentration: 0%
Estimate against measurement, compound 4: 75 percentage points above, and the stated range ends above it.
By their numbers in this assay, from the lowest: compound 4; then compound 1; then compound 2; then compound 3.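

In this assay, the aromatic carbon that carries the nitro group proves far more sensitive than the earlier step suggested: chloro in place of nitro gives a number 72 percentage points lower from compound 2 to compound 4 (beyond the scatter) and leaves no growth inhibition at the concentration tested. With 4-chlorophenyl in place of naphthalen-1-yl, the result is a number 95 percentage points lower from compound 3 to compound 4 (beyond the scatter), so a phenyl ring with a group at this position does not by itself preserve inhibition: 4-nitrophenyl does, while 4-chlorophenyl does not. Nothing available explains why these two groups behave so differently.

On these data alone, it remains open whether the loss is particular to chloro or would also appear with an amine or a carboxylic acid on this carbon. Results at a single concentration also leave open how these compounds would compare at lower concentrations.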